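Swapping an Indole for Fluorophenyl on a Weak Series

The source may hold more compounds than are shown below. What is called first, only, known or untested is meant among the compounds shown, and "the series" means these compounds.

Compound 1, `COc1ccc(-c2nc(C(=O)/C=C\Nc3ccc4[nH]ccc4c3)c3ccccn23)cc1`, gives 13000 nM in a functional assay on BT-474 cells (Homo sapiens) for cytotoxicity, read by MTT assay, with a stated time of 48 h; a lower number here means a stronger inhibitor, a higher number a weaker inhibitor.
Compound 2, `O=C(/C=C\Nc1ccc2cc[nH]c2c1)c1nc(-c2ccc(C(F)(F)F)cc2)n2ccccc12`, is reported in this assay only as a limit, > 30000 nM.
Compound 3, `COc1ccc(N/C=C\C(=O)c2nc(-c3ccc(OC)cc3)n3ccccc23)cc1`, gives 15400 nM in this assay.

All three share one core and differ in the group on the amine nitrogen and in the group on the outer phenyl ring. Compound 2 stands at the edge of what this assay can report: its entry is a limit rather than a number, namely (the limit of > 30000 nM in this assay, at which 1 of the 3 values shown sits). Compound 4, `O=C(/C=C\Nc1ccc(F)cc1)c1nc(-c2ccc(C(F)(F)F)cc2)n2ccccc12`, follows from compound 2 by a single change: 4-fluorophenyl in place of 1H-indol-6-yl on an amine nitrogen. One measured step resembles this exchange. It is a 1.2-fold higher number from compound 1 to compound 3 (0.07 log units; within the scatter), where an indolyl on the same amine nitrogen likewise gives way to a phenyl carrying a small substituent, and the numbers stay within the scatter. On that evidence no move beyond the scatter is expected in this assay, and the expected step is a number no higher from compound 2 to compound 4 (the limit leaves the size open). Compound 4 is therefore estimated at 30000 nM, between 15000 nM and 60000 nM, and it is expected most likely to come back as a limit rather than a number.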

Compound 4, half-maximal inhibitory concentration: > 30000 nM
Compound 4: no number, only a limit; the forecaster's own chance of this, stated with the estimate: 70%; the middle value sits exactly at the limit.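

In this assay, going by these compounds alone, compound 2 and compound 4 both come back only as limits, so no step between them can be read: the limit of > 30000 nM in this assay, at which 2 of the 4 values shown sit. The compounds shown leave open where either of these two truly stands, and so whether 4-fluorophenyl in place of 1H-indol-6-yl on the amine nitrogen changes the number at all.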